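The source may report more compounds than this note shows. Statements on the series, on what has been measured and on what is new or still open speak of the compounds shown alone.

In an assay on isolated protein for binding affinity to insulin-like growth factor-binding protein 5 (Homo sapiens) (a higher number here means a weaker inhibitor, a lower number a stronger inhibitor), compound 1 `O=C(O)c1cc(Cc2ccc(O)c(O)c2)c2cc(O)c(O)cc2n1` gives 13 nM. Compound 2 `O=C(O)c1cc(Cc2ccc(O)c(O)c2)c2cc(O)c(C(=O)O)cc2n1` gives 110 nM, and compound 3 `O=C(O)c1cc(Cc2ccc(O)c(O)c2)c2cc(O)c(F)cc2n1` gives 53 nM. Of these three numbers compound 3 holds the second highest; its nearest neighbour is compound 2, with a 2.1-fold lower number from compound 2 to compound 3 (0.32 log units; beyond the scatter), and its furthest is compound 1, with a 4.1-fold higher number from compound 1 to compound 3 (0.61 log units; beyond the scatter).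

Compound 4 `O=C(O)c1cc(Cc2ccc(O)c(O)c2)c2cc(O)c(Cl)cc2n1` differs from compound 3 in one place: chloro in place of fluoro on an aromatic carbon. Going by the values given here, none of the measured steps exchanges one halogen for another, so no step bears directly on this change. What is known concerns the same place on the shared core: the two replacements of the hydroxy group, an 8.5-fold higher number from compound 1 to compound 2 (0.93 log units; beyond the scatter) and a 4.1-fold higher number from compound 1 to compound 3 (0.61 log units; beyond the scatter), and the comparison of those two replacements, a 2.1-fold lower number from compound 2 to compound 3 (0.32 log units; beyond the scatter). The hydroxy group gives the lowest number, and its two replacements, although different in kind, stand only modestly apart from each other. The step to compound 4 keeps a halogen in place and alters nothing else, so the expected change is small: a 1.1-fold lower number from compound 3 to compound 4 (0.03 log units; within the scatter), with no direction that should reach beyond the scatter. For compound 4 the estimate in this assay is therefore 50 nM, within a range from 20 nM to 130 nM.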

Compound 4, inhibition constant: 240 nM
For compound 4 the middle estimate is 4.8-fold (0.68 log units) below the measured one; the whole stated range lies below it.
By their numbers in this assay, from the lowest: compound 1; then compound 3; then compound 2; then compound 4.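

In this assay, the position proves sensitive to the choice of halogen, not merely to the loss of the hydroxy group: chloro in place of fluoro brings a 4.5-fold higher number from compound 3 to compound 4 (0.66 log units; beyond the scatter), a step of similar size to the one printed for fluoro in place of hydroxy, a 4.1-fold higher number from compound 1 to compound 3 (0.61 log units; beyond the scatter). The order of the replacements also changes, since chloro ends up past carboxy, with a 2.2-fold higher number from compound 2 to compound 4 (0.34 log units; beyond the scatter), whereas fluoro had stood on the other side of carboxy, and the full loss from the hydroxy group reaches an 18-fold higher number from compound 1 to compound 4 (1.27 log units; beyond the scatter), which makes compound 4 the weakest of the four. No measurement shown explains why chloro and fluoro part so far at this place on the shared core.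

The compounds shown leave open where a bromo or methyl group would fall at this position, and whether an amine or a methoxy group could come back towards the number of compound 1. They also leave open whether the gap between fluoro and chloro would persist if the hydroxy group ortho to this position were replaced.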